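This account rests on a few compounds, and the source may have more. Where it says the series, first, only, none or still open, it means among the compounds named here.

Compounds measured in a physicochemical assay for lipophilicity, read by HPLC, measured as octanol-water partition; a higher number here means a more lipophilic compound, a lower number a more polar compound:
compound 1 `CCN1CCN(C[C@H]2CN(c3ccc(-n4cc(-c5ccccn5)cn4)c(F)c3)C(=O)O2)CC1`: 2.19
compound 2 `O=C1O[C@@H](CNC(=O)C(F)(F)F)CN1c1ccc(-n2cc(-c3ccccn3)cn2)c(F)c1`: >= 1.78, a limit of the assay and not a number

Among the compounds with values here, compound 1 holds the only read number in this assay. For compound 2 the value sits at the limit of >= 1.78 in this assay, at which 1 of the 2 values shown sits. Compound 3 `NC(=O)[C@H]1CN(c2ccc(-n3cc(-c4ccccn4)cn3)c(F)c2)C(=O)O1` differs from compound 1 as carbamoyl in place of (4-ethylpiperazin-1-yl)methyl on a saturated ring carbon. Within the data shown here, the single measured step, a step that the limit leaves unreadable from compound 1 to compound 2, has no readable size and so gives neither direction nor magnitude for the new step. The expectation for compound 3 therefore rests on the value of compound 1 alone. A modest fall is estimated, a number 0.59 log units lower from compound 1 to compound 3 (beyond the scatter). Compound 3 is expected at 1.6, within 1 to 2.2.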

Compound 3, partition coefficient: 1.59
The estimate for compound 3 lay 0.01 log units above the measured number, within the range that was stated.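

Within the data shown here, on the saturated ring carbon next to the ring oxygen, carbamoyl in place of (4-ethylpiperazin-1-yl)methyl gives, in this assay, the first readable step at this position: a number 0.60 log units lower from compound 1 to compound 3 (beyond the scatter). Carbamoyl in place of (((trifluoromethyl)carbonyl)amino)methyl gives a number at least 0.19 log units lower from compound 2 to compound 3 (that floor lies within the scatter), which fixes only a floor. Compound 2 stands at a limit of the assay and not a number: the limit of >= 1.78 in this assay, at which 1 of the 3 values shown sits.

The step between compound 1 and compound 2 cannot be read, and one readable step cannot separate the share of the leaving group from that of the entering group. As far as these compounds go, how a carboxylic acid or a simple aminomethyl group on this ring carbon would read in this assay remains open.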